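This account rests on a few compounds, and the source may have more. Where it says the series, first, only, none or still open, it means among the compounds named here.

For the measured compounds named here, in a functional assay on PC-3 cells (Homo sapiens) for cytotoxicity, read by MTT assay, with a stated time of 72 h (a lower number here means a stronger inhibitor, a higher number a weaker inhibitor), compound 1 `CCc1ccc(-c2cc(C(=O)Nc3ccc(Oc4ccnc(C(=O)NC)c4)c(F)c3)ncn2)cc1` gives 15600 nM and compound 2 `CNC(=O)c1cc(Oc2ccc(NC(=O)c3cc(-c4ccccc4)ncn3)cc2F)ccn1` gives 44300 nM, so compound 2 holds the higher of the two numbers known so far and is the weaker inhibitor of the pair. Compound 3 `CNC(=O)c1cc(Oc2ccc(NC(=O)c3cc(-c4ccc(F)cc4)ncn3)cc2F)ccn1` differs from compound 2 at a single place: fluoro in place of hydrogen on an aromatic carbon. Here the phenyl of compound 2 becomes 4-fluorophenyl. Going by the values given here, only one measured step bears on this change, and it concerns the same ring: a 2.8-fold higher number from compound 1 to compound 2 (0.45 log units; beyond the scatter). That modest step shows that the compound with hydrogen there was the weaker one. Fluoro is a different group from ethyl, so this single step is only a loose guide. A modest shift to a lower number in this assay is therefore expected, and it may not clear the scatter. The estimated step is a 1.5-fold lower number from compound 2 to compound 3 (0.18 log units; within the scatter). For compound 3, the expected value is 29000 nM, with an estimated range of 13000 nM to 60000 nM.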

Compound 3, half-maximal inhibitory concentration: > 100000 nM
Compound 3: only a limit was reported; the forecaster's own chance of this, stated with the estimate: 10%; middle value at least 3.4-fold (0.53 log units) from the limit.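

In this assay, this place on the ring does not reward every replacement for hydrogen. Ethyl compares favourably with hydrogen, as a 2.8-fold higher number from compound 1 to compound 2 (0.45 log units; beyond the scatter) shows, whereas fluoro, a single added atom, moves the other way, with an at least 2.2-fold higher number from compound 2 to compound 3 (0.35 log units; beyond the scatter). Set directly against ethyl, fluoro gives an at least 6.4-fold higher number from compound 1 to compound 3 (0.80 log units; beyond the scatter), so the earlier gain from ethyl does not carry over to 4-fluorophenyl, and the result for compound 3 is a limit of the assay, not a number: the limit of > 100000 nM in this assay, at which 1 of the 3 values shown sits.

The compounds shown leave open whether a longer chain such as propyl, or a group such as methoxy or an amine at this place, would behave like ethyl or like fluoro. Going by these compounds, how large the two steps to compound 3 really are also remains open.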